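Swapping nitro for chloro on the anilide ring

The compounds below may be only part of what the source reports. "The series", "measured", "known", "first", "only" and "open" are said of these compounds alone.

Measured compounds:
- compound 1, `O=C(/C=C/C(=O)N1C/C(=C\c2ccccc2)C(=O)/C(=C/c2ccccc2)C1)Nc1ccc([N+](=O)[O-])cc1`: 40000 nM
- compound 2, `Cc1ccc(NC(=O)/C=C/C(=O)N2C/C(=C\c3ccc([N+](=O)[O-])cc3)C(=O)/C(=C/c3ccc([N+](=O)[O-])cc3)C2)cc1C`: 4900 nM
- compound 3, `Cc1ccc(NC(=O)/C=C/C(=O)N2C/C(=C\c3ccc([N+](=O)[O-])cc3)C(=O)/C(=C/c3ccc([N+](=O)[O-])cc3)C2)cc1`: 4400 nM

All three share a core in which two benzylidene arms flank a ketone on a six-membered ring carrying an unsaturated diamide linker to an anilide. In a functional assay on L1210 cells (Mus musculus) for cytotoxicity (on this read-out lower numbers stand for stronger inhibition and higher numbers for weaker inhibition), compound 1 gives 40000 nM, the highest number of the three. Compound 2 gives 4900 nM and compound 3 gives 4400 nM, both well below compound 1 and beyond the scatter from it. Compound 2 and compound 3 differ from compound 1 in two places at once, so neither alone tells what the anilide substituent does.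

Within the data shown here, the only single-site step available is a 1.1-fold lower number from compound 2 to compound 3 (0.05 log units; within the scatter), where the anilide ring loses a methyl; this step stays within the scatter. It suggests that changing a substituent on that ring moves the number little, although it is not the same change as the one at hand.

Compound 4, `O=C(/C=C/C(=O)N1C/C(=C\c2ccccc2)C(=O)/C(=C/c2ccccc2)C1)Nc1ccc(Cl)cc1`, differs from compound 1 by chloro in place of nitro on an aromatic carbon. Among the measured compounds shown here, with no measured pair showing this exchange, a small step is expected in this assay, and compound 4 is estimated at 25000 nM (range 8000 nM to 80000 nM), corresponding to an expected step of a 1.6-fold lower number from compound 1 to compound 4 (0.20 log units; within the scatter).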

Compound 4, half-maximal inhibitory concentration: 7800 nM
Compound 4: the middle estimate sits 3.2-fold (0.51 log units) above what was measured; the whole stated range lies above it.
By their numbers in this assay, from the lowest: compounds 3, 2 and 4 (each within the scatter of the next); then compound 1.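

Among these compounds, the exchange of 4-nitrophenyl for 4-chlorophenyl gives the first step beyond the scatter that involves only the anilide ring (a 5.1-fold lower number from compound 1 to compound 4 (0.71 log units; beyond the scatter) in this assay), so the group at this place, para to a large group, does matter for the number on the shared core. Among the compounds shown here, the only earlier single-site step (a 1.1-fold lower number from compound 2 to compound 3 (0.05 log units; within the scatter)) was the loss of a methyl and stayed within the scatter, and the new result shows that this quiet step cannot be carried over to every substituent change on this ring. Nothing at hand explains the size of the new step, and no measurement points to a cause.

As far as these compounds go, with only nitro and chloro compared at this place, two points cannot show a trend, and it remains open how a plain hydrogen, an amine, a methoxy group or a carboxylic acid would read there. From the compounds shown here alone, it is also open whether chloro in place of nitro moves the number by a similar amount when the benzylidene arms carry nitro groups, as they do in compound 2 and compound 3.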